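The source may report more compounds than this note shows. Statements on the series, on what has been measured and on what is new or still open speak of the compounds shown alone.

Compound 3, `CC1=C(C(=O)SC(C)C)C(c2cccs2)NC(=O)N1`, is the point of departure. In an assay on membranes from CHO cells for displacement of a labelled ligand from adenosine receptor A1 (Homo sapiens), read by scintillation counting, with a stated time of 60 min, tested at 1 uM (a higher number here means more inhibition at the concentration tested (going by the name of the read-out), a lower number less inhibition), compound 3 gives 1%, which leaves it level with compound 1, `CCNC(=O)C1=C(C)NC(=O)NC1c1cccs1`, whose value in this assay is 1%, with no change at the digits printed from compound 1 to compound 3 (within the scatter). Compound 2, `CC1=C(C(=O)NC(C)C)C(c2cccs2)NC(=O)N1`, gives 2% in this assay, and the step of a number 1 percentage points lower from compound 2 to compound 3 (within the scatter) is likewise within the scatter. Together compound 3 and compound 1 hold the lowest of the three numbers, but none of the three is separated from the others beyond the scatter.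

Compound 4, `CC1=C(c2ncc(C)o2)C(c2cccs2)NC(=O)N1`, differs from compound 3 in one place: 5-methyl-1,3-oxazol-2-yl in place of (isopropylsulfanyl)carbonyl on a double-bonded ring carbon. Among the measured compounds shown here, none of the measured steps bears directly on this exchange. For the measured compounds named here, the two steps from compound 1 and the step from compound 2 all vary the group attached to the carbonyl carbon or the chain on its nitrogen, and all of them stayed within the scatter; no measured compound carries an aromatic ring in place of the carbonyl at this position. With every measured value near the bottom of the scale and every measured step flat, the expectation for compound 4 in this assay is a step of a number 2 percentage points higher from compound 3 to compound 4 (within the scatter), that is, none beyond the scatter. Compound 4 is therefore estimated at 3%, within a range from -5% to 15%.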

Compound 4, a percentage reported as inhibition, at one concentration (the size of the read-out at that concentration, not a potency): 21%
Compound 4: the middle estimate sits 18 percentage points below what was measured; the measured number lies above the stated range.
By their numbers in this assay, from the lowest: compounds 1, 3 and 2 (each within the scatter of the next); then compound 4.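

At this double-bonded ring carbon, the changes within the carbonyl-bearing group had all stayed within the scatter, but replacing that group outright with 5-methyl-1,3-oxazol-2-yl moves the number in this assay beyond it, with a number 20 percentage points higher from compound 3 to compound 4 (beyond the scatter). The same exchange gives a number 19 percentage points higher from compound 2 to compound 4 (beyond the scatter) against isopropylcarbamoyl and a number 20 percentage points higher from compound 1 to compound 4 (beyond the scatter) against ethylcarbamoyl, so the thioester-type group and both amide-type groups all sit on the same side of this change, and the leaving (isopropylsulfanyl)carbonyl and the entering ring have equal counts of heavy atoms, hydrogen-bond donors and hydrogen-bond acceptors, which therefore do not separate them. No measurement available here accounts for the rise.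

As far as these compounds go, whether the five-membered aromatic ring or its methyl group carries the rise remains open, as does whether an unsubstituted 1,3-oxazol-2-yl, a thiazole or a phenyl at this carbon would give a similar number. Also open, from the compounds shown here alone, is whether the rise would hold with a phenyl or a furan in place of the thiophen-2-yl group, and what potency lies behind a percentage read at a single concentration.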